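A 2,4-dimethylphenyl swap among compounds at the limit

A few compounds are considered here, and "the series" means these few. Any claim that something is new, unique, unknown or untested is made for them only; others in the source may bear on it.

Measured in a functional assay on OVCAR-3 cells (Homo sapiens) for antiproliferative activity, read by spectrophotometry, with a stated time of 2 days; on this read-out lower numbers stand for stronger inhibition of growth and higher numbers for weaker inhibition of growth:
- compound 1 `COc1ccc(Nc2ncc(C(F)(F)F)c(N3Cc4cccc(N(C)S(C)(=O)=O)c4C3)n2)cc1C(F)(F)F`: > 30000 nM, a limit
- compound 2 `Cc1ccc(Nc2ncc(C(F)(F)F)c(N3Cc4cccc(N(C)S(C)(=O)=O)c4C3)n2)c(Cl)c1`: > 30000 nM, a limit
- compound 3 `CN(c1cccc2c1CN(c1nc(Nc3ccc(C(F)(F)F)cc3)ncc1C(F)(F)F)C2)S(C)(=O)=O`: > 30000 nM, a limit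

Compound 3 gives > 30000 nM, which is a limit of the assay and not a number. The same holds across the series, which shows (the limit of > 30000 nM in this assay, at which 3 of the 3 values shown sit).

Compound 4 `Cc1ccc(Nc2ncc(C(F)(F)F)c(N3Cc4cccc(N(C)S(C)(=O)=O)c4C3)n2)c(C)c1` has 2,4-dimethylphenyl in place of 4-(trifluoromethyl)phenyl on a nitrogen on an aromatic ring.

Three measured steps change this same group. For the measured compounds named here, the first is a step that the two limits leave unreadable from compound 2 to compound 3, and compound 2 carries 2-chloro-4-methylphenyl. The others are a step that the two limits leave unreadable from compound 1 to compound 3 and a step that the two limits leave unreadable from compound 1 to compound 2. None of them has a readable size, so they support no direction and no step beyond the usual scatter. The expected change is a number no higher from compound 3 to compound 4 (the limit leaves the size open).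

A report of only a limit is the likeliest outcome for the new compound in this assay. The estimate for compound 4 is 30000 nM, with an expected range from 10000 nM to 60000 nM.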

Compound 4, concentration for 50% growth inhibition: > 30000 nM
Compound 4: only a limit was reported; the forecaster's own chance of this, stated with the estimate: 85%; the middle value sits exactly at the limit.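

In this assay compound 4 gives > 30000 nM, which is a limit and not a number. No step from compound 1, compound 2 or compound 3 to compound 4 can be read, because all four compounds stop at the same point: the limit of > 30000 nM in this assay, at which 4 of the 4 values shown sit.

The compounds shown leave open whether any of these groups on the nitrogen gives stronger inhibition of growth than another.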